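A Fluoro for Hydrogen on the Phenoxy Ring

A few compounds are considered here, and "the series" means these few. Any claim that something is new, unique, unknown or untested is made for them only; others in the source may bear on it.

Measured compounds:
compound 1 `c1ccc(Oc2ccc3c(NCCCNCc4ccco4)ccnc3c2)cc1`: 317 10^-6 cm/s
compound 2 `COc1cccc(CNCCCNc2ccnc3cc(Oc4ccc(Cl)cc4)ccc23)c1O`: 317 10^-6 cm/s
compound 3 `COc1ccc(F)cc1CNCCCNc1ccnc2cc(C3CCCCC3)ccc12`: 23 10^-6 cm/s

Three compounds have been run in an ADME assay for permeability, using PAMPA, with a stated time of 30 min, at pH 7.4; a lower number here means that the compound crosses the layer more slowly, a higher number that the compound crosses the layer faster. Compound 1 gives 317 10^-6 cm/s, and compound 2 gives 317 10^-6 cm/s, the same figure at the digits shown, so the two cannot be told apart and together they stand at the top of the three. Among the compounds with values here, compound 3 gives 23 10^-6 cm/s, which is well below the other two and outside the usual scatter; no single-point step connects it to compound 1, so only the two values themselves can be compared.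

The next compound, compound 4 `Fc1ccc(Oc2ccc3c(NCCCNCc4ccco4)ccnc3c2)cc1`, is derived from compound 1 by one change: fluoro in place of hydrogen on an aromatic carbon. Within the data shown here, no pair already measured shows this change, so its effect has to be judged from the starting point alone. Since compound 1 already sits at 317 10^-6 cm/s, the step of no change at the digits printed from compound 1 to compound 4 (within the scatter) is expected to be small and to stay within the scatter of repeated measurements. Compound 4 is therefore estimated at 317 10^-6 cm/s, with a range from 160 10^-6 cm/s to 550 10^-6 cm/s.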

Compound 4, apparent permeability: 317 10^-6 cm/s
Compound 4: middle estimate and measured number agree at the digits printed, within the range that was stated.
By their numbers in this assay, from the lowest: compound 3; then compounds 1, 2 and 4 (each within the scatter of the next).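

Among the compounds shown, only this pair differs in one place, so it gives a direct reading where the earlier compounds offered only separate values: in this assay, the change from phenoxy to 4-fluorophenoxy gives no change at the digits printed from compound 1 to compound 4 (within the scatter) for fluoro in place of hydrogen. At this position, on an aromatic carbon para to a large group, the added fluorine atom therefore produces no step beyond the scatter in this one pair. Nothing available explains this result.

Going by these compounds, whether an amine or a carboxylic acid at the same position would read the same remains open. Also open, on these data alone, is whether fluoro in place of hydrogen would give the same result elsewhere on the phenoxy ring, or in a compound with a different side chain.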